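The compounds below may be only part of what the source reports. "The series", "measured", "known", "first", "only" and "open" are said of these compounds alone.

Measured so far in a physicochemical assay for lipophilicity, read by HPLC, at pH 7.4; a lower number here means a more polar compound, a higher number a more lipophilic compound:
compound 1 `CC(C)Cc1cc2oc(=O)n(CCC(=O)O)c2cc1Cl` gives 3.03
compound 2 `C[C@@H](Oc1cc2onc(CCC(=O)O)c2cc1Cl)c1ccc(Cl)cn1` gives 2.91
compound 3 `C[C@@H](Oc1cc2c(cc1Cl)N(CCC(=O)O)C(=O)CO2)c1ccccn1` gives 1.56

Compound 1 holds the highest number of the three. The value of compound 2 lies within the scatter of it, so the two cannot be told apart; compound 3 sits well beyond the scatter, far toward the polar side. Among the measured compounds shown here, no pair of these three differs in one place only, so no single-change step is available from the measured set.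

For the measured compounds named here, compound 4 `O=C(O)CCn1c(=O)oc2cc(OCC3CCC3)c(Cl)cc21` is the one unmeasured compound. It is built from compound 1 by one change: cyclobutylmethoxy in place of isobutyl on an aromatic carbon

The change swaps one side chain for a slightly larger one that brings an ether oxygen and a small ring. Nothing measured here isolates such a swap, so the expectation rests on compound 1 alone. The step from compound 1 to compound 4 is expected to be small, a slight move toward the polar side or none beyond the scatter, estimated as a number 0.13 log units lower from compound 1 to compound 4 (within the scatter).

For compound 4 in this assay the expected value is 2.9, with a range from 2.5 to 3.3.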

Compound 4, distribution coefficient: 2.9
The estimate for compound 4 equals the measured number at the digits printed; the measured number falls inside the stated range.
By their numbers in this assay, from the lowest: compound 3; then compounds 4, 2 and 1 (each within the scatter of the next).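

In this assay, among the compounds shown here, this is the first step that can be read in one place: cyclobutylmethoxy in place of isobutyl, on the aromatic carbon ortho to the chloro group, gives a number 0.13 log units lower from compound 1 to compound 4 (within the scatter). The entering group brings an ether oxygen, a hydrogen-bond acceptor and a four-membered non-aromatic ring that isobutyl does not have, yet compound 1 and compound 4 cannot be told apart in this measurement, so on this core the position accepts this exchange of side chains without a readable shift in the number. No measured evidence is available that bears on the size of this step.

As far as these compounds go, the ether oxygen and the four-membered ring arrive together here, so their separate contributions remain open; an isobutoxy group or a cyclobutylethyl chain on the same aromatic carbon would pull them apart. Also open, from the compounds shown here alone, is whether a side chain at this carbon carrying an amine or a hydroxyl group would give a step beyond the scatter, and whether the same exchange would read alike on the cores of compound 2 and compound 3.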